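Trading Acetyl for Methoxycarbonyl at the Assay Limit

This account rests on a few compounds, and the source may have more. Where it says the series, first, only, none or still open, it means among the compounds named here.

In an ADME assay on Raji cells (Homo sapiens) for cytotoxicity, with a stated time of 72 h (a lower number here means that less compound is needed, a higher number that more compound is needed for the effect), compound 1 `CC(=O)c1ccc(NC(=O)Nc2cc(C)nc3ccccc23)cc1` gives > 25000 nM, which is a limit of the assay and not a number. Compound 2 `Cc1cc(NC(=O)Nc2cccc([N+](=O)[O-])c2)c2ccccc2n1` gives > 25000 nM, again a limit. Compound 3 `Cc1cc(NC(=O)Nc2ccc3[nH]cnc3c2)c2ccccc2n1` gives > 25000 nM, also a limit. Compound 1 therefore stands with these two relatives at the limit of > 25000 nM in this assay, at which 3 of the 3 values shown sit, so none of the three has an exact figure.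

Compound 4 `COC(=O)c1ccc(NC(=O)Nc2cc(C)nc3ccccc23)cc1` has not yet been measured. It keeps the core of compound 1 and changes a single group, acetyl to methoxycarbonyl: methoxy in place of methyl on a carbonyl carbon. Put simply, methoxy takes the place of methyl on a carbonyl carbon.

Among the measured compounds shown here, no measured pair of compounds differing in one place is available as a guide. With compound 1 at > 25000 nM, a limit, no step beyond the usual scatter is expected in this assay. The expected change a number no higher from compound 1 to compound 4 (the limit leaves the size open) is an estimate and should stay within that scatter. For compound 4 the expected value is 25000 nM, with an estimated range from 12000 nM to 50000 nM.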

Compound 4, half-maximal effective concentration: 17000 nM
Compound 4: the middle estimate sits 1.5-fold (0.17 log units) above what was measured; the measured number falls inside the stated range.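

Methoxy in place of methyl on a carbonyl carbon gives the only exact figure so far in this assay: compound 4 reads 17000 nM. As far as these compounds go, the change amounts to an at least 1.4-fold lower number from compound 1 to compound 4 (0.16 log units; that floor lies within the scatter), and that number is only a floor, so the true size of the step remains unknown. This single change therefore gives one reading that can be placed on a scale, while the other compounds remain at a shared limit: the limit of > 25000 nM in this assay, at which 3 of the 4 values shown sit.

From the compounds shown here alone, it remains open what hydroxy at this carbonyl carbon, which would make a carboxylic acid, or an amine there, which would make an amide, would read, and whether the longer ethoxy would shift the number further. With one exact figure, the compounds shown cannot tell whether this reading is particular to methoxy.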